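Notes on compounds 1 to 3: chloro versus nitro

This account rests on a few compounds, and the source may have more. Where it says the series, first, only, none or still open, it means among the compounds named here.

Measured so far:
compound 1 `O=C(O)CCc1cccc2c1B(O)OC2`: > 100000 nM in a functional assay on SK-OV-3 cells (Homo sapiens) for antiproliferative activity, read by MTT assay, with a stated time of 72 h; on this read-out higher numbers stand for weaker inhibition and lower numbers for stronger inhibition
compound 2 `O=C(CCc1cccc2c1B(O)OC2)Nc1ccc(Cl)cc1`: 5000 nM in this assay

In this assay compound 1 sits at a limit of the assay, (the limit of > 100000 nM in this assay, at which 1 of the 2 values shown sits), and gives no number. Compound 2 therefore stands alone: its value in this assay is the only actual number shown, the remaining value being a limit.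

Compound 3 `O=C(CCc1cccc2c1B(O)OC2)Nc1ccc([N+](=O)[O-])cc1` differs from compound 2 by nitro in place of chloro on an aromatic carbon. Within the data shown here, no measured pair shares this change, so its size cannot be read from the data; the step expected in this assay is none beyond the usual scatter, in either direction. Compound 3 is estimated at 5000 nM, with a range from 1500 nM to 16000 nM. The expected step is no change at the digits printed from compound 2 to compound 3 (within the scatter).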

Compound 3, half-maximal inhibitory concentration: 83000 nM
Beside the measured number, compound 3's estimate is 17-fold (1.22 log units) below it, outside the stated range (above it).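

The aromatic carbon para to a large group proves sensitive to what it carries: nitro in place of chloro gives a 17-fold higher number from compound 2 to compound 3 (1.22 log units; beyond the scatter) in this assay. Among these compounds, this single pair is the first readable step, and it favours chloro over nitro at this position. Compound 3 at 83000 nM is still a number and not a limit, so the step can be read in full: the limit of > 100000 nM in this assay, at which 1 of the 3 values shown sits.

Only chloro and nitro are shown here, so the cause of the step cannot be read. Going by these compounds, whether an amine, a methoxy group or a fluoro group at this position would sit closer to compound 2 or to compound 3 remains open.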